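Nitro in Place of Hydroxy: What Compound 4 May Show

This account rests on a few compounds, and the source may have more. Where it says the series, first, only, none or still open, it means among the compounds named here.

Measured compounds:
compound 1 `O=c1cc(CNCc2cccc(O)c2)oc2ccc(O)c(O)c12` — > 100000 nM, a limit of the assay
compound 2 `O=c1cc(CNCc2cccc([N+](=O)[O-])c2)oc2ccc(O)c(O)c12` — > 100000 nM, a limit of the assay
compound 3 `O=c1cc(CNCc2ccc(O)cc2)oc2ccc(O)c(O)c12` — 62700 nM

In an ADME assay on Huh-7 cells (Homo sapiens) for cytotoxicity (a higher number here means that more compound is tolerated, a lower number that less compound is tolerated), compound 1 gives > 100000 nM, which is a limit rather than a number. Compound 2 likewise gives > 100000 nM, also a limit. Going by the values given here, compound 3 gives 62700 nM, the only number among the three. The two cores differ as 4-hydroxyphenyl in place of 3-hydroxyphenyl on a saturated chain carbon bound to an amine nitrogen, and that step is an at least 1.5-fold lower number from compound 1 to compound 3 (0.20 log units; that floor lies within the scatter). The change nitro in place of hydroxy on an aromatic carbon yields a step that the two limits leave unreadable from compound 1 to compound 2, because of the limit of > 100000 nM in this assay, at which 2 of the 3 values shown sit. Compound 4 `O=c1cc(CNCc2ccc([N+](=O)[O-])cc2)oc2ccc(O)c(O)c12` carries the same kind of change, (nitro in place of hydroxy on an aromatic carbon), but here the group sits para to a large group, whereas in compound 2 it sits meta to a large group. The step is expected to be a 1.3-fold higher number from compound 3 to compound 4 (0.11 log units; within the scatter), resting on compound 3 at 62700 nM. Compound 4 is estimated at 80000 nM, expected between 30000 nM and 200000 nM.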

Compound 4, half-maximal cytotoxic concentration: 73300 nM
The estimate for compound 4 lay 1.1-fold (0.04 log units) above the measured number, within the range that was stated.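

Nitro in place of hydroxy, para to a large group, gives a 1.2-fold higher number from compound 3 to compound 4 (0.07 log units; within the scatter) in this assay, so compound 3 and compound 4 cannot be told apart on this core. The same change on the core of compound 1 gives no readable step, and the data therefore do not show that its outcome carries from one core to the other, because both compounds of that pair sit at a limit of the assay: the limit of > 100000 nM in this assay, at which 2 of the 4 values shown sit. A single readable step on a single core sets no trend for the series.

As far as these compounds go, whether an amine or a carboxylic acid in place of the nitro would give a number that stands beyond the scatter from compound 3 remains open. So does what a longer chain on the amine nitrogen of the shared core would give in this assay.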